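The source may report more compounds than this note shows. Statements on the series, on what has been measured and on what is new or still open speak of the compounds shown alone.

Compound 1, `COc1cc(C)cc(-c2nn(CC#N)cc2-c2ccc(-c3cccc(C(C)=O)c3)nc2)c1`, in a functional assay on NCI-H23 cells (Homo sapiens) for inhibition, read by sulforhodamine B assay, with a stated time of 48 h (on this read-out lower numbers stand for higher toxicity in this test and higher numbers for lower toxicity in this test), gives > 100000 nM, which is a limit of the assay.
Compound 2, `Cc1cc(O)cc(-c2nn(CC#N)cc2-c2ccnc(-c3ccc(Oc4ccccc4)cc3)c2)c1`, in this assay gives 8130 nM.
Compound 3, `COc1cc(C)cc(-c2nn(CC#N)cc2-c2ccnc(-c3ccc(N(C)C)cc3)c2)c1`, in this assay gives > 100000 nM, again a limit of the assay and not a number.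

Compound 3 therefore stands at the edge of what this assay can report: its value is a limit, and the limit of > 100000 nM in this assay, at which 2 of the 3 values shown sit, describes how two of the three values shown sit there. Only compound 2 gives a number inside the range of the test. The step to compound 4, `Cc1cc(O)cc(-c2nn(CC#N)cc2-c2ccnc(-c3ccc(N(C)C)cc3)c2)c1`, is hydrogen in place of methyl on an oxygen on an aromatic ring. Going by the values given here, no measured pair differs in this one place, so the size of the step is not known from the data. Among the compounds with values here, compound 2, the one compound carrying the hydroxy, is also the one with a value inside the range, though it differs from compound 4 in a second place as well. Compound 4 is therefore expected to move toward stronger toxicity in this assay, with an at least 2.5-fold lower number from compound 3 to compound 4 (0.39 log units; beyond the scatter) as the expected step, yet it may still land at the limit. The estimated value of compound 4 in this assay is 40000 nM, between 8000 nM and 150000 nM.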

Compound 4, concentration lethal to 50% of the cells: > 100000 nM
Compound 4: no number, only a limit; the forecaster's own chance of this, stated with the estimate: 45%; middle value at least 2.5-fold (0.39 log units) from the limit.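

In this assay compound 4 gives > 100000 nM, which is a limit of the assay and not a number. The step from methoxy to hydroxy cannot be read, as both of its ends are limits, so with dimethylamino in the other place, the hydroxy does not by itself yield a value inside the range of the test. The new pair reads the other place instead: with the 3-hydroxy-5-methylphenyl held fixed, dimethylamino in place of phenoxy on an aromatic carbon gives an at least 12-fold higher number from compound 2 to compound 4 (1.08 log units; beyond the scatter), so in this pair it is the phenoxy that goes with a number inside the range, and the ceiling of the test now holds most of the series: the limit of > 100000 nM in this assay, at which 3 of the 4 values shown sit.

The compounds shown leave open whether methoxy to hydroxy changes anything in this assay, for no pair with that change has a number at both ends. They also leave open whether the phenoxy is specifically required, or whether a benzyloxy group or a longer alkoxy chain in that place would also give a value inside the range.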